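A new aromatic group on compound 1

The source may hold more compounds than are shown below. What is called first, only, known or untested is meant among the compounds shown, and "the series" means these compounds.

- compound 1 `COc1ccccc1/C=C(/Sc1ccc(C)cc1)C(=O)c1ccc(Br)cc1` gives 9000 nM
- compound 2 `COc1ccccc1/C=C(/Sc1ccc(C)cc1)C(=O)c1ccc(Cl)cc1` gives 25000 nM

In a functional assay on DU-145 cells (Homo sapiens) for inhibition, read by trypan blue exclusion, with a stated time of 96 h (a higher number here means a weaker inhibitor of growth, a lower number a stronger inhibitor of growth), compound 1 has the lower of the two numbers, so it is the stronger growth inhibitor of this pair. Among the measured compounds shown here, compound 3 `CC(=O)c1ccc(/C=C(/Sc2ccc(C)cc2)C(=O)c2ccc(Br)cc2)cc1` keeps the bromo but carries 4-acetylphenyl in place of 2-methoxyphenyl on a double-bonded chain carbon bound to a double-bonded chain carbon as its one change. For the measured compounds named here, the only measured step of a 2.8-fold higher number from compound 1 to compound 2 (0.44 log units; beyond the scatter) is modest and swaps chloro for bromo, so it does not test this change. No direction can be predicted, and the range must stay wide. The estimated step is a 1.1-fold higher number from compound 1 to compound 3 (0.05 log units; within the scatter) and carries little confidence. Compound 3 is expected at 10000 nM (estimated range 3000 nM to 35000 nM).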

Compound 3, concentration for 50% growth inhibition: 50000 nM
The estimate for compound 3 lay 5.0-fold (0.70 log units) below the measured number, and the stated range ends below it.
By their numbers in this assay, from the lowest: compound 1; then compounds 2 and 3 (each within the scatter of the next).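

In this assay, the aromatic group on this double-bonded chain carbon matters as well as the halogen: 4-acetylphenyl in place of 2-methoxyphenyl brings a 5.6-fold higher number from compound 1 to compound 3 (0.74 log units; beyond the scatter) and so gives a weaker inhibitor of growth. No measurement here explains this loss.

Because the change removes the methoxy group and adds an acetyl group in one step, the compounds shown cannot say which of the two drives the result. Going by these compounds, it also remains open how an unsubstituted phenyl ring, or an amine or carboxylic acid on this ring, would fare.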